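The compounds below may be only part of what the source reports. "The series", "measured", "known", "first", "only" and "open" are said of these compounds alone.

Two compounds share a core in which a benzoyl group is joined through a carbon–carbon double bond to a further chain. Compound 1 `O=C(/C=C/C1CCCCC1)c1ccccc1` gives 15000 nM in a functional assay on T47D cells (Homo sapiens) for inhibition, read by sulforhodamine B assay, with a stated time of 48 h; on this read-out lower numbers stand for stronger inhibition of growth and higher numbers for weaker inhibition of growth. Compound 2 `O=C(/C(=C/C1CCCCC1)CCl)c1ccccc1` gives 29000 nM in this assay. As written, compound 2 carries the larger of the two numbers, but its gap to compound 1 lies within the usual scatter of repeated measurements, so the two values show no real separation.

Compound 3 `O=C(/C(=C/c1ccccc1)CCl)c1ccccc1` has not yet been measured. It differs from compound 2 by phenyl in place of cyclohexyl on a double-bonded chain carbon bound to a double-bonded chain carbon. Among the measured compounds shown here, no measured pair shows this kind of change, so its effect can only be guessed. A modest step toward a lower number is expected, with little confidence that it will exceed the scatter. Compound 3 is therefore estimated at 15000 nM, within a range from 4000 nM to 50000 nM. The step this estimate implies is expected to be a 1.9-fold lower number from compound 2 to compound 3 (0.29 log units; within the scatter).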

Compound 3, concentration for 50% growth inhibition: 18000 nM
Compound 3: middle estimate off by 1.2-fold (0.08 log units), on the low side; the range from low to high includes it.
By their numbers in this assay, from the lowest: compounds 1, 3 and 2 (each within the scatter of the next).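

Phenyl in place of cyclohexyl on a double-bonded chain carbon bound to a double-bonded chain carbon brings a 1.6-fold lower number from compound 2 to compound 3 (0.21 log units; within the scatter) in this assay, so this first measured change at this position shows no real separation between the aromatic ring and the non-aromatic ring. On this read-out, compound 2 and compound 3 cannot be told apart, and the position tolerates this exchange without a change that exceeds the scatter. Nothing among the data shown accounts for this result.

The compounds shown leave open whether any group at this carbon can move the number beyond the scatter, such as a longer chain, an amine or a carboxylic acid. They also leave open whether a phenyl ring carrying a methoxy group or a fluorine atom would behave as the unsubstituted phenyl of compound 3 does.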